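The source may report more compounds than this note shows. Statements on the series, on what has been measured and on what is new or still open speak of the compounds shown alone.

In a functional assay on A549 cells (Homo sapiens) for cytotoxicity, read by MTT assay, with a stated time of 72 h (a lower number here means a stronger inhibitor, a higher number a weaker inhibitor), compound 1 `COc1cc2c(Oc3ccc(NC(=O)c4cn(-c5ccccc5)nn4)cc3F)ccnc2cc1OCCCN1CCCC1` gives 360 nM, and compound 2 `COc1cc2c(Oc3ccc(NC(=O)c4cn(-c5ccccc5)nn4)cc3F)ccnc2cc1OCCCN1CCCCC1` gives 130 nM. For the measured compounds named here, the single measured step, a 2.8-fold lower number from compound 1 to compound 2 (0.44 log units; beyond the scatter), leaves compound 2 with the lower of the two numbers. Compound 3 `COc1cc2c(Oc3ccc(NC(=O)c4cn(-c5ccc(Br)cc5)nn4)cc3F)ccnc2cc1OCCCN1CCCCC1` carries bromo in place of hydrogen on an aromatic carbon. Going by the values given here, no measured step touches the phenyl on the triazole; the only step concerns the amine at the end of the chain and says nothing about this position. For compound 3 a step within the scatter is therefore expected, no change at the digits printed from compound 2 to compound 3 (within the scatter), with no set direction. Compound 3 is estimated in this assay at 130 nM, with a range of 45 nM to 400 nM.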

Compound 3, half-maximal inhibitory concentration: 230 nM
Beside the measured number, compound 3's estimate is 1.8-fold (0.25 log units) below it, within the range that was stated.
By their numbers in this assay, from the lowest: compounds 2, 3 and 1 (each within the scatter of the next, the first and the last beyond it).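

Bromo in place of hydrogen on the phenyl, para to a large group, gives in this assay a 1.8-fold higher number from compound 2 to compound 3 (0.25 log units; within the scatter). For the compounds shown here, this is the first reading at this position, and with a single added bromine the 4-bromophenyl of compound 3 does not separate from the phenyl of compound 2. No supporting evidence accompanies this result.

On these data alone, whether a methoxy or an amine in place of the bromo would separate from compound 2 stays open. So does whether bromo reads the same alongside the pyrrolidin-1-yl of compound 1.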